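From Methylsulfonyl to Methylsulfanyl: Expected Binding Change

The source may hold more compounds than are shown below. What is called first, only, known or untested is meant among the compounds shown, and "the series" means these compounds.

Compound 1 `CSc1ccc(C)cc1NCC1=NCCN1`: 977 nM
Compound 2 `CS(=O)(=O)c1ccc(C(F)(F)F)cc1NCC1=NCCN1`: < 6310 nM

In an assay on CHO cells for binding affinity to Alpha-2B adrenergic receptor (Homo sapiens), read by radioligand binding (a lower number here means a stronger inhibitor, a higher number a weaker inhibitor), compound 1 gives 977 nM. For compound 2 the assay reports only a limit, < 6310 nM, so compound 2 stands at the limit of < 6310 nM in this assay, at which 1 of the 2 values shown sits, rather than at a number. Compound 3, `CSc1ccc(C(F)(F)F)cc1NCC1=NCCN1`, is not yet measured; it differs from compound 2 by methylsulfanyl in place of methylsulfonyl on an aromatic carbon. Among the measured compounds shown here, no measured pair shows this change, so its size is unknown from the data, and compound 1 is the only compound carrying methylsulfanyl with a number. Compound 3 is expected near 1200 nM, within 300 nM to 5000 nM. That estimate means an expected step that the limit leaves unreadable from compound 2 to compound 3.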

Compound 3, inhibition constant: 1660 nM
For compound 3 the middle estimate is 1.4-fold (0.14 log units) below the measured one; the measured number falls inside the stated range.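

Trifluoromethyl in place of methyl on an aromatic carbon, with methylsulfanyl kept, gives a 1.7-fold higher number from compound 1 to compound 3 (0.23 log units; within the scatter) in this assay and so makes no clear difference to the binding number. Methylsulfanyl now has a measured number alongside each of these two groups. Compound 2 has only the limit < 6310 nM and no number, so the step from methylsulfonyl to methylsulfanyl cannot be read.

On these data alone, no readable pair changes methylsulfanyl itself, so its own contribution stays open. Also open, as far as these compounds go, is how an amine or a carboxylic acid would fare in its place.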